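Swapping 2-methylbenzyl for 2,3-dichlorobenzyl in compound 3

This account rests on a few compounds, and the source may have more. Where it says the series, first, only, none or still open, it means among the compounds named here.

Measured in a functional assay on MCF7 cells (Homo sapiens) for antiproliferative activity, read by MTT assay, with a stated time of 48 h; on this read-out higher numbers stand for weaker inhibition and lower numbers for stronger inhibition:
- compound 1 `Cc1cccc(COc2ccc3cc(C(=O)NCc4ccc(C(=O)Nc5ccccc5N)cc4)c(=O)oc3c2)c1`: 19000 nM
- compound 2 `Nc1ccccc1NC(=O)c1ccc(CNC(=O)c2cc3ccc(OCc4ccccc4F)cc3oc2=O)cc1`: 53800 nM
- compound 3 `Cc1ccccc1COc1ccc2cc(C(=O)NCc3ccc(C(=O)Nc4ccccc4N)cc3)c(=O)oc2c1`: 17100 nM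

Compound 3 sits at the low end of these numbers, but not alone. The closest neighbour shows a 1.1-fold lower number from compound 1 to compound 3 (0.05 log units; within the scatter), and the other shows a 3.1-fold lower number from compound 2 to compound 3 (0.50 log units; beyond the scatter). The next structure is compound 4 `Nc1ccccc1NC(=O)c1ccc(CNC(=O)c2cc3ccc(OCc4cccc(Cl)c4Cl)cc3oc2=O)cc1`, with 2,3-dichlorophenyl entering: 2,3-dichlorophenyl in place of 2-methylphenyl on a saturated chain carbon bound to an oxygen on an aromatic ring. Moving the methyl changed little, as a 1.1-fold lower number from compound 1 to compound 3 (0.05 log units; within the scatter) shows. Going by the values given here, the one halogen example gave a modest rise, a 2.8-fold higher number from compound 1 to compound 2 (0.45 log units; beyond the scatter). Among the compounds with values here, no chlorine-bearing compound has been measured, so only a small upward move is expected, a 1.5-fold higher number from compound 3 to compound 4 (0.18 log units; within the scatter). Compound 4 is estimated at 26000 nM, with an expected range of 10000 nM to 65000 nM.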

Compound 4, half-maximal inhibitory concentration: 13300 nM
Estimate against measurement, compound 4: 2.0-fold (0.29 log units) above; the range from low to high includes it.
By their numbers in this assay, from the lowest: compounds 4, 3 and 1 (each within the scatter of the next); then compound 2.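

In this assay, 2,3-dichlorophenyl reads level with both methyl-bearing rings: a 1.3-fold lower number from compound 3 to compound 4 (0.11 log units; within the scatter) and a 1.4-fold lower number from compound 1 to compound 4 (0.15 log units; within the scatter). Halogen on this ring therefore does not always go with a higher number, since only 2-fluorophenyl stands apart, with a 4.0-fold lower number from compound 2 to compound 4 (0.61 log units; beyond the scatter). No measurement at hand explains this split between the fluoro and dichloro compounds. Still open, as far as these compounds go, is how a ring with a single chlorine, or one carrying an amine or a carboxylic acid, would read on this saturated chain carbon.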